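Adding an Amino Group to the Aryl Ring of Compound 3

This account rests on a few compounds, and the source may have more. Where it says the series, first, only, none or still open, it means among the compounds named here.

In a functional assay on MCF7 cells (Homo sapiens) for inhibition, read by CCK-8 assay, with a stated time of 48 h (on this read-out lower numbers stand for stronger inhibition and higher numbers for weaker inhibition), compound 3 `COc1ccc(-c2cc3nccc(-c4cc(OC)c(OC)c(OC)c4)n3n2)cc1` gives 125 nM and compound 2 `COc1cc(-c2ccnc3cc(-c4cn(C)c5ccccc45)nn23)cc(OC)c1OC` gives 95 nM. The gap between them is a 1.3-fold higher number from compound 2 to compound 3 (0.12 log units; within the scatter). Compound 1 `COc1cc(-c2ccnc3cc(-c4ccc(C(F)(F)F)cc4)nn23)cc(OC)c1OC` stands well apart from this pair at 2440 nM.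

Compound 4 `COc1ccc(-c2cc3nccc(-c4cc(OC)c(OC)c(OC)c4)n3n2)cc1N` carries amino in place of hydrogen on an aromatic carbon of compound 3, turning 4-methoxyphenyl into 3-amino-4-methoxyphenyl: amino in place of hydrogen on an aromatic carbon. The new group sits ortho to a methoxy group and meta to a large group.

Among the measured compounds shown here, no measured pair tests an amino group, so the evidence is indirect. Two large steps, a 20-fold lower number from compound 1 to compound 3 (1.29 log units; beyond the scatter) and a 26-fold lower number from compound 1 to compound 2 (1.41 log units; beyond the scatter), both leave the 4-(trifluoromethyl)phenyl group and show that a change at this aryl group can move the number widely. In contrast, the replacement of 1-methyl-1H-indol-3-yl by 4-methoxyphenyl, a 1.3-fold higher number from compound 2 to compound 3 (0.12 log units; within the scatter), shows that a substantial change can also leave it almost unmoved.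

From the compounds shown here alone, on this thin basis, no step beyond the scatter is expected in this assay, though a wide range must stay open in both directions. The expected step is a 1.6-fold lower number from compound 3 to compound 4 (0.19 log units; within the scatter). For compound 4 the estimated value is 80 nM, with an expected range of 20 nM to 320 nM.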

Compound 4, half-maximal inhibitory concentration: 27 nM
Compound 4: the middle estimate sits 3.0-fold (0.47 log units) above what was measured; the range from low to high includes it.
By their numbers in this assay, from the lowest: compound 4; then compounds 2 and 3 (each within the scatter of the next); then compound 1.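

In this assay, amino in place of hydrogen on the 4-methoxyphenyl group gives a step beyond the scatter (a 4.6-fold lower number from compound 3 to compound 4 (0.67 log units; beyond the scatter)), so a single added group at this place, ortho to a methoxy group, can move the number even though the exchange of 1-methyl-1H-indol-3-yl for 4-methoxyphenyl did not. With 3-amino-4-methoxyphenyl, the aryl group now also separates from 1-methyl-1H-indol-3-yl beyond the scatter (a 3.5-fold lower number from compound 2 to compound 4 (0.55 log units; beyond the scatter)), and the distance from the 4-(trifluoromethyl)phenyl group widens further (a 90-fold lower number from compound 1 to compound 4 (1.96 log units; beyond the scatter)). No measurement at hand accounts for the size of these steps.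

What stays open is whether this step is specific to amino: a hydroxy group, a dimethylamino group or an acetamide at the same place could each read differently, and the compounds shown do not separate these cases. From the compounds shown here alone, it is also open whether amino gives a similar step with the aryl group in other forms, for example without the neighbouring methoxy group, as 3-aminophenyl.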